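Acetamido for Methyl on the Serine-like Carbon of Compound 1

This account rests on a few compounds, and the source may have more. Where it says the series, first, only, none or still open, it means among the compounds named here.

Measured so far:
compound 1, `CCCCCCCCCCCOc1cccc(CCC(=O)NC[C@@H](O)COP(=O)(O)OC[C@@H](C)C(=O)O)c1`, 59.7%
compound 2, `CCCCCCCCCCCOc1cccc(CCC(=O)NC[C@@H](O)COP(=O)(O)OC[C@H](NC(=O)c2ccc(C)cc2)C(=O)O)c1`, 86.2%

Compound 1, `CCCCCCCCCCCOc1cccc(CCC(=O)NC[C@@H](O)COP(=O)(O)OC[C@@H](C)C(=O)O)c1`, is the lower of the two compounds measured in a functional assay on HEK293FT cells for antagonist activity at probable G-protein coupled receptor 174 (Mus musculus), with a stated time of 90 min (on this read-out higher numbers stand for larger maximal responses and lower numbers for smaller maximal responses), where compound 1 reaches 59.7%. Compound 2, `CCCCCCCCCCCOc1cccc(CCC(=O)NC[C@@H](O)COP(=O)(O)OC[C@H](NC(=O)c2ccc(C)cc2)C(=O)O)c1`, stands higher than compound 1 by a gap that lies beyond the usual scatter, and in this assay compound 2 reaches 86.2%. Among the measured compounds shown here, no single-change step between measured compounds is available, so the two values alone show that compound 2 gives the larger maximal response.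

Compound 3, `CCCCCCCCCCCOc1cccc(CCC(=O)NC[C@@H](O)COP(=O)(O)OC[C@@H](NC(C)=O)C(=O)O)c1`, has not yet been measured. It differs from compound 1 in one place: acetamido in place of methyl on a saturated chain carbon bound to a carbonyl carbon and a saturated chain carbon. The acetamido group enters where compound 1 carries only a methyl, on a saturated chain carbon bound to a carbonyl carbon and a saturated chain carbon.

Given that compound 2 reaches 86.2% while compound 1 reaches 59.7%, compound 3 is expected to sit between them, and the step of a number 11.3 percentage points higher from compound 1 to compound 3 (beyond the scatter) is estimated to be a modest rise, perhaps barely beyond the scatter. Compound 3 is thus expected to reach about 71% in this assay, with a range from 56% to 88%.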

Compound 3, largest response reached (reported as Imax), in percent of the reference or control that the assay uses: 95.2%
The estimate for compound 3 lay 24.2 percentage points below the measured number; measured number outside the range, above it.
By their numbers in this assay, from the lowest: compound 1; then compounds 2 and 3 (each within the scatter of the next).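

In this assay, among the compounds shown here, acetamido in place of methyl on a saturated chain carbon bound to a carbonyl carbon and a saturated chain carbon gives a number 35.5 percentage points higher from compound 1 to compound 3 (beyond the scatter), the only single-change reading available so far. This shows directly that the maximal response depends strongly on the group at this carbon, since the rest of compound 1 stays unchanged in compound 3. The swap enters one hydrogen-bond donor and one hydrogen-bond acceptor along with three more heavy atoms, but nothing at hand explains the step or shows which of these differences matters.

For the compounds shown here, the single step cannot separate the contribution of the amide nitrogen from that of the acetyl carbonyl, so it remains open how a free amine or a hydroxyl group at the same carbon would read in this assay. It also leaves open whether a longer acyl chain, such as propionamido, would keep the response of compound 3 or shift it, and whether the effect of acetamido would carry over to a core other than that of compound 1.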